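Lengthening the chain from compound 3 to compound 4

The source may hold more compounds than are shown below. What is called first, only, known or untested is meant among the compounds shown, and "the series" means these compounds.

Compound 3 `CCCCOc1cc(OC)ccc1C(C)=O` gives 43300000 nM in a functional assay, with a stated time of 30 min (on this read-out higher numbers stand for weaker inhibition and lower numbers for stronger inhibition), and sits level with the two other measured compounds. Compound 1 `CCCCOc1cc(OC)c(Br)cc1C(C)=O` gives 42300000 nM and compound 2 `CCOc1cc(OC)ccc1C(C)=O` gives 39600000 nM on the same read-out, so all three numbers lie within the scatter of one another.

Compound 4 `CCCCCCCCCCOc1cc(OC)ccc1C(C)=O` differs from compound 3 by one change: hexyl in place of hydrogen on a saturated chain carbon, four bonds along the chain from an oxygen on an aromatic ring with the hexyl entering on a saturated chain carbon, four bonds along the chain from an oxygen on an aromatic ring.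

Within the data shown here, two measured steps bear on this. The closer one is a 1.1-fold higher number from compound 2 to compound 3 (0.04 log units; within the scatter) with ethyl in place of hydrogen on a saturated chain carbon, two bonds along the chain from an oxygen on an aromatic ring. It stays within the scatter. The step of a 1.0-fold higher number from compound 1 to compound 3 (0.01 log units; within the scatter) with hydrogen in place of bromo on an aromatic carbon also stays within the scatter, but it concerns a different place.

No step beyond the scatter is expected in this assay because a 1.1-fold higher number from compound 2 to compound 3 (0.04 log units; within the scatter) is so small. Hexyl is a larger addition than ethyl, and no measured compound carries a chain of this length, so the range is kept wide. The expected step is a 1.2-fold lower number from compound 3 to compound 4 (0.08 log units; within the scatter) and no more than scatter. For compound 4 the estimated value is 36000000 nM (expected range 12000000 nM to 75000000 nM).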

Compound 4, half-maximal inhibitory concentration: 40100000 nM
Estimate against measurement, compound 4: 1.1-fold (0.05 log units) below, within the range that was stated.
By their numbers in this assay, from the lowest: compounds 2, 4, 1 and 3 (each within the scatter of the next).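

In this assay, hexyl in place of hydrogen on a saturated chain carbon, four bonds along the chain from an oxygen on an aromatic ring, gives a 1.1-fold lower number from compound 3 to compound 4 (0.03 log units; within the scatter), so a hydrocarbon addition of 6 heavy atoms at this position leaves the read-out within the scatter. The earlier chain step, a 1.1-fold higher number from compound 2 to compound 3 (0.04 log units; within the scatter), covered only an ethyl addition, and the flat result on this chain now extends from ethyl to hexyl across compound 2, compound 3 and compound 4. No measured evidence bearing on why the read-out stays flat along this chain is available.

All chain changes shown are plain hydrocarbon, so it remains open whether a polar group at the chain end, such as an amine or a carboxylic acid, would produce a step beyond the scatter at this position. The bromo change, a 1.0-fold higher number from compound 1 to compound 3 (0.01 log units; within the scatter), is also shown only on the butyl-bearing compounds, which leaves open whether it would stay within the scatter on the chain of compound 4, and whether replacing the acetyl carbonyl of the shared core with an amide would move the read-out at all.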